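A few compounds are considered here, and "the series" means these few. Any claim that something is new, unique, unknown or untested is made for them only; others in the source may bear on it.

Compound 3 `C=C1C[C@]23C[C@@]1(O)CC[C@H]2c1ccc(OS(=O)(=O)c2ccc(C)cc2)c(C)c1[C@@H]3Cn1cc(-c2ccc(C)cc2)nn1` carries a ((4-methylphenyl)sulfonyl)oxy group on the aromatic ring. In a functional assay on HL-60 cells (Homo sapiens) for cytotoxicity, read by MTT assay, with a stated time of 4 days (a higher number here means a weaker inhibitor, a lower number a stronger inhibitor), compound 3 gives > 20000 nM, a limit of the assay and not a number. Compound 1 `C=C1C[C@]23C[C@@]1(O)CC[C@H]2c1ccc(OS(=O)(=O)c2ccc(C)cc2)c(C)c1[C@@H]3Cn1cc(-c2ccc(Br)cc2)nn1` gives > 20000 nM in this assay, likewise a limit. Compound 2 `C=C1C[C@]23C[C@@]1(O)CC[C@H]2c1cc(Br)c(O)c(C)c1[C@@H]3Cn1cc(-c2ccc(C)cc2)nn1` gives > 20000 nM, also a limit. The step that the two limits leave unreadable from compound 1 to compound 3 thus cannot be sized, since both ends sit at the limit of > 20000 nM in this assay, at which 3 of the 3 values shown sit. Compound 4 `C=C1C[C@]23C[C@@]1(O)CC[C@H]2c1ccc(O)c(C)c1[C@@H]3Cn1cc(-c2ccc(C)cc2)nn1` differs from compound 3 by hydrogen in place of (4-methylphenyl)sulfonyl on an oxygen on an aromatic ring. Going by the values given here, no measured step bears on this change. Compound 2, which carries a free hydroxy, rests at its limit of > 20000 nM. Compound 4 is therefore expected to remain near the limit, with an estimated step of a number no higher from compound 3 to compound 4 (the limit leaves the size open) that is unlikely to be readable. The estimate for compound 4 in this assay is 20000 nM, expected between 5000 nM and 60000 nM.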

Compound 4, half-maximal inhibitory concentration: > 20000 nM
Compound 4: a limit, no number; the forecaster's own chance of this, stated with the estimate: 70%; the middle value lies on the limit itself.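

No step can be read between compound 4 and compound 3 or compound 2, as all values remain limits: the limit of > 20000 nM in this assay, at which 4 of the 4 values shown sit.
The compounds shown leave open whether any change on the shared core gives a number rather than a limit in this assay.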